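Swapping a pyridine for an indole in a cytotoxicity series

The compounds below may be only part of what the source reports. "The series", "measured", "known", "first", "only" and "open" are said of these compounds alone.

Measured so far:
Compound 1, `CCOC(=O)CCCCCOc1cccc(CN(C(=O)c2ccc(-c3cccnc3)cc2)C(C)C)c1`, gives > 26000 nM.
Compound 2, `CCOC(=O)CCCCCOc1cccc(CN(C(=O)c2ccc(-c3cccc(OCc4ccccc4)c3)cc2)C(C)C)c1`, gives > 26000 nM.

Both numbers come from an ADME assay on HepG2 cells (Homo sapiens) for cytotoxicity, read by CellTiter-Glo and resazurin assay, with a stated time of 72 h; a lower number here means that less compound is needed, a higher number that more compound is needed for the effect. For compound 1 the value is a limit of this assay, not a measured number, so compound 1 simply sits at the limit of this assay. The same holds for compound 2, whose value is also a limit. This is summed up by the limit of > 26000 nM in this assay, at which 2 of the 2 values shown sit: neither compound shows a measurable effect within the tested range.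

Compound 3, `CCOC(=O)CCCCCOc1cccc(CN(C(=O)c2ccc(-c3ccc4[nH]ccc4c3)cc2)C(C)C)c1`, is not yet measured. It differs from compound 1 in one place: 1H-indol-5-yl in place of pyridin-3-yl on an aromatic carbon.

Within the data shown here, since no step between two measured compounds exists here, the expected direction rests only on what compound 1 and compound 2 show. Both remain at the limit despite carrying different groups at this position, so no step beyond the scatter is expected for compound 3 in this assay. Compound 3 is therefore expected to give about 30000 nM in this assay, with a likely range from 12000 nM to 80000 nM. The step from compound 1 to compound 3 that this estimate means is a step that the limit leaves unreadable from compound 1 to compound 3, which is expected to stay within the scatter.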

Compound 3, half-maximal effective concentration: > 26000 nM
Compound 3 ended at the assay's limit; the forecaster's own chance of this, stated with the estimate: 75%; the middle value does not contradict the limit.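

Compound 1 and compound 3 both sit at a limit of this assay, so the change from pyridin-3-yl to 1H-indol-5-yl gives no step that can be read: the limit of > 26000 nM in this assay, at which 3 of the 3 values shown sit.

The compounds shown leave open how much of any of them it takes to produce the effect, and whether any group at this place changes that amount.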